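The source may hold more compounds than are shown below. What is called first, only, known or untested is meant among the compounds shown, and "the series" means these compounds.

Measured compounds:
- compound 1 `Cc1c(COc2cccc(OCC3CCOCC3)c2)[nH]c2ccc(C(=O)O)cc2c1=O`: < 20 mL/min/kg
- compound 2 `Cc1ccc2[nH]c(COc3cccc(OCC4CCOCC4)c3)c(C)c(=O)c2c1`: "not determined" (no result reported)
- compound 3 `COc1ccc2[nH]c(COc3cccc(OCC4CCOCC4)c3)c(C)c(=O)c2c1`: "not determined" (no result reported)

In an in vitro ADME assay on microsomes from liver (Homo sapiens) for metabolic stability, tested at 0.2 uM (on this read-out lower numbers stand for slow clearance and higher numbers for fast clearance), compound 1 reaches only (the limit of < 20 mL/min/kg in this assay, at which 1 of the 3 values shown sits), which is a limit of the assay rather than a number. Compound 2 has no result in this assay. Compound 3 likewise has no result, so it stands nowhere on the numbers shown, and the only measured value in the set is the limit for compound 1. Compound 4 `Cc1c(COc2cccc(OCC3CCOCC3)c2)[nH]c2ccc(Cl)cc2c1=O` differs from compound 3 by chloro in place of methoxy on an aromatic carbon. Going by the values given here, with no measured step to lean on, no shift beyond the scatter of this assay is expected between the two. Compound 4 is estimated at 18 mL/min/kg in this assay, within a range of 6 mL/min/kg to 45 mL/min/kg.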

Compound 4, clearance: > 1000 mL/min/kg
Compound 4 gave a limit, no number; the forecaster's own chance of this, stated with the estimate: 45%; at least 55-fold (1.74 log units) between middle value and limit.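

In this assay, this aromatic carbon now gives its first readable step, with chloro in place of carboxy: an at least 50-fold higher number from compound 1 to compound 4 (1.69 log units; beyond the scatter), so the group held there goes with a change in this read-out far beyond the scatter. Compound 4 stands at a limit, not a number: the limit of > 1000 mL/min/kg in this assay, at which 1 of the 4 values shown sits. Compound 1 also stands at a limit, not a number: the limit of < 20 mL/min/kg in this assay, at which 1 of the 4 values shown sits.

The step from compound 3 to compound 4 cannot be read: compound 3 has no result. On these data alone, the true size of the step stays open, as does whether an amide or a nitrile on this carbon would lie nearer compound 1 or compound 4.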